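The compounds below may be only part of what the source reports. "The series", "measured", "known", "first", "only" and "open" are said of these compounds alone.

Of the compounds shown here, two built on the shared core have been tested so far, compound 1 `CC[C@@H](Nc1nc(SC)nc2c1ccn2[C@H]1[C@H](O)[C@H](O)[C@]2(CO)C[C@H]12)C1CC1` and compound 2 `CC(C)(O)[C@@H](Nc1nc(Cl)nc2c1ccn2[C@H]1[C@H](O)[C@H](O)[C@]2(CO)C[C@H]12)C1CC1`. In an ADME assay on Vero 76 cells (Chlorocebus sabaeus) for cytotoxicity, read by microscopy (a lower number here means that less compound is tolerated, a higher number that more compound is tolerated), compound 2 gives > 100000 nM, which is a limit of the assay and not a number. Its exact place on the scale is therefore unknown.

The next compound, compound 3 `CSc1nc(N[C@@H](C2CC2)C(C)(C)O)c2ccn([C@H]3[C@H](O)[C@H](O)[C@]4(CO)C[C@H]34)c2n1`, keeps the (1-cyclopropyl-2-hydroxy-2-methylpropyl)amino group of compound 2 and changes one group on the core: methylsulfanyl in place of chloro on an aromatic carbon. This puts methylsulfanyl in place of chloro on an aromatic carbon, between two ring nitrogen atoms.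

For the measured compounds named here, no measured pair shows this change on its own, so the only guide is indirect. Compound 1 already carries methylsulfanyl at that place, alongside a different amino group, and it gives > 50000 nM, which is also a limit. With no number yet seen for either compound, no clear shift in either direction is expected. The estimated step of a number no higher from compound 2 to compound 3 (the limit leaves the size open) stays within the usual scatter. In this assay, the expected value for compound 3 is 100000 nM, with an estimated range from 50000 nM to 150000 nM.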

Compound 3, half-maximal cytotoxic concentration: > 100000 nM
Compound 3 gave a limit, no number (the forecaster's own chance of this, stated with the estimate: 85%); the middle value lies on the limit itself.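

In this assay compound 3 gives > 100000 nM, which is a limit of the assay and not a number. The steps to compound 3 from compound 1 and from compound 2 therefore cannot be read. The compounds shown leave open how much of each is actually tolerated, and whether methylsulfanyl in place of chloro changes that.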